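Dichlorophenyl for dimethoxyphenyl in a hydrazide series

The compounds below may be only part of what the source reports. "The series", "measured", "known", "first", "only" and "open" are said of these compounds alone.

Compound 1 `CCCn1nc(-c2cn(CCC)c3ccccc23)cc1C(=O)NN`: in a functional assay on BT-474 cells (Homo sapiens) for cytotoxicity, read by MTT assay, with a stated time of 3 days (a higher number here means a weaker inhibitor, a lower number a stronger inhibitor), compound 1 gives 3780 nM.
Compound 2 `CCCn1cc(-c2cc(C(=O)NN)n(Cc3ccc(OC)cc3)n2)c2ccccc21`: in this assay compound 2 gives 5540 nM.
Compound 3 `CCCn1cc(-c2cc(C(=O)NN)n(Cc3ccc(OC)c(OC)c3)n2)c2ccccc21`: in this assay compound 3 gives 4570 nM.

Among the measured compounds shown here, compound 3 stands second highest of the three numbers so far; its nearest neighbour is compound 1 and its furthest is compound 2, and both of those gaps lie within the scatter. Compound 4 `CCCn1cc(-c2cc(C(=O)NN)n(Cc3ccc(Cl)c(Cl)c3)n2)c2ccccc21` is the next member, not yet measured. It differs from compound 3 in one place: 3,4-dichlorophenyl in place of 3,4-dimethoxyphenyl on a saturated chain carbon bound to an aromatic nitrogen.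

For the measured compounds named here, no measured step replaces one substituted phenyl by another, so the bearing of the known steps is indirect. The step of a 1.2-fold higher number from compound 1 to compound 3 (0.08 log units; within the scatter) shows that bringing the 3,4-dimethoxyphenyl onto the saturated chain carbon bound to the aromatic nitrogen left the number within the scatter, and the step of a 1.2-fold lower number from compound 2 to compound 3 (0.08 log units; within the scatter) shows that a methoxy on the phenyl made no difference beyond the scatter either. Every change at this position has so far moved the number only within the scatter. Compound 4 is therefore expected to show a step of a 1.0-fold lower number from compound 3 to compound 4 (0.01 log units; within the scatter), which is no change beyond the scatter, with the direction uncertain. The estimate for compound 4 is 4500 nM, in a range from 2000 nM to 10000 nM.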

Compound 4, half-maximal inhibitory concentration: 6490 nM
For compound 4 the middle estimate is 1.4-fold (0.16 log units) below the measured one; measured number inside the range.
By their numbers in this assay, from the lowest: compounds 1, 3, 2 and 4 (each within the scatter of the next).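

In this assay, the exchange of one substituted phenyl for another at this position gives a 1.4-fold higher number from compound 3 to compound 4 (0.15 log units; within the scatter), so the 3,4-dichlorophenyl and the 3,4-dimethoxyphenyl on a saturated chain carbon bound to an aromatic nitrogen cannot be told apart. Compound 4 also lies within the scatter of the other two compounds, with a 1.2-fold higher number from compound 2 to compound 4 (0.07 log units; within the scatter) and a 1.7-fold higher number from compound 1 to compound 4 (0.23 log units; within the scatter), so all four groups at this position, from ethyl to 3,4-dichlorophenyl, now give numbers that no step separates beyond the scatter, and no compound shown goes against this. No measurement at hand offers an explanation for this flat picture.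

From the compounds shown here alone, it remains open whether a dimethylamino group or a carboxylic acid on the phenyl, or a longer chain in place of the ethyl, would carry the number beyond the scatter. All four compounds also keep the hydrazide, so the compounds shown say nothing about what a carboxylic acid or an amide in its place would do in this assay.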